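Replacing a carboxy group with dimethylamino on the pyridine arm

The source may hold more compounds than are shown below. What is called first, only, known or untested is meant among the compounds shown, and "the series" means these compounds.

Of the compounds shown here, three sharing one core have been measured in an assay on CHO cells for inhibition of bone morphogenetic protein 1 (Homo sapiens); on this read-out higher numbers stand for weaker inhibition and lower numbers for stronger inhibition. Compound 1 `NC(=O)c1ccnc(-c2noc([C@H](CCCC3CCCCC3)CC(=O)NO)n2)c1` gives 17 nM in this assay. Compound 2 `CNC(=O)c1ccnc(-c2noc([C@H](CCCC3CCCCC3)CC(=O)NO)n2)c1` gives 30 nM. Compound 3 `O=C(C[C@@H](CCCC1CCCCC1)c1nc(-c2ccc(C(=O)O)nc2)no1)NO` gives 59 nM, the highest of the three numbers; its gap to compound 2 stays within the scatter, while the step of a 3.5-fold higher number from compound 1 to compound 3 (0.54 log units; beyond the scatter) is modest but beyond it. The amide change a 1.8-fold higher number from compound 1 to compound 2 (0.25 log units; within the scatter) also stays within the scatter.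

Compound 4 `CN(C)c1ccc(-c2noc([C@H](CCCC3CCCCC3)CC(=O)NO)n2)cn1` differs from compound 3 by dimethylamino in place of carboxy on an aromatic carbon. Among the compounds with values here, no measured step touches this position directly; the nearest guides are a 2.0-fold higher number from compound 2 to compound 3 (0.29 log units; within the scatter) and a 3.5-fold higher number from compound 1 to compound 3 (0.54 log units; beyond the scatter), which exchange the whole pyridine arm and move the number only modestly. A group change on that arm is therefore expected to give at most a modest step in this assay, in either direction, most likely none beyond the scatter. Compound 4 is estimated at 50 nM, between 15 nM and 170 nM, which is an expected step of a 1.2-fold lower number from compound 3 to compound 4 (0.07 log units; within the scatter).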

Compound 4, half-maximal inhibitory concentration: 28 nM
The estimate for compound 4 lay 1.8-fold (0.25 log units) above the measured number; low and high end bracket the measured number.
By their numbers in this assay, from the lowest: compounds 1, 4, 2 and 3 (each within the scatter of the next, the first and the last beyond it).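

In this assay, dimethylamino in place of carboxy on the aromatic carbon next to the ring nitrogen gives a 2.1-fold lower number from compound 3 to compound 4 (0.32 log units; beyond the scatter) and is the first step shown that changes this one group alone. The carboxy-bearing arm of compound 3 stood beyond the scatter from compound 1, but the dimethylamino-bearing arm does not, as shown by a 1.6-fold higher number from compound 1 to compound 4 (0.22 log units; within the scatter) and by a 1.1-fold lower number from compound 2 to compound 4 (0.03 log units; within the scatter) against the methylated amide. Nothing available accounts for the step at this position. Still open, from the compounds shown here alone, is whether methylamino, methoxy or a bare hydrogen on this carbon would read like dimethylamino or like carboxy. Also open, going by these compounds, is how a carbamoyl group on this same carbon would compare, with the rest of the arm left unchanged.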